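Dimethylamino on the Benzylidene Arm of Compound 2

This account rests on a few compounds, and the source may have more. Where it says the series, first, only, none or still open, it means among the compounds named here.

Measured in a functional assay on L1210 cells (Mus musculus) for cytotoxicity, with a stated time of 48 h; a higher number here means a weaker inhibitor, a lower number a stronger inhibitor:
compound 1 `COc1cc(/C=C2\CCC/C(=C\c3ccccc3[N+](=O)[O-])C2=O)cc(OC)c1OC`: 1520 nM
compound 2 `O=C1/C(=C/c2ccccc2)CCC/C1=C\c1ccc([N+](=O)[O-])cc1`: 9800 nM
compound 3 `O=C1/C(=C/c2ccc(Cl)cc2)CCC/C1=C\c1ccccc1[N+](=O)[O-]`: 9380 nM

Compound 2 has the highest number of the three in this assay. Its value and that of compound 3 lie within the scatter of each other, so no order can be read between them, while compound 1 gives a number well below both. Compound 4 `CN(C)c1ccc(/C=C2\CCC/C(=C\c3ccc([N+](=O)[O-])cc3)C2=O)cc1` is not yet measured; it differs from compound 2 by dimethylamino in place of hydrogen on an aromatic carbon. Among the measured compounds shown here, no measured pair shows this change, so its size can only be guessed. Compound 4 is expected to give a moderately lower number than compound 2, a step of about a 2.5-fold lower number from compound 2 to compound 4 (0.39 log units; beyond the scatter) in this assay. Compound 4 is estimated at 4000 nM, between 1000 nM and 15000 nM.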

Compound 4, half-maximal inhibitory concentration: > 500000 nM
Compound 4: a limit, no number; the forecaster's own chance of this, stated with the estimate: 5%; middle value at least 120-fold (2.09 log units) from the limit.
By their numbers in this assay, from the lowest: compound 1; then compounds 3 and 2 (each within the scatter of the next). At a limit, above all of these: compound 4.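

In this assay, dimethylamino in place of hydrogen on an aromatic carbon, para to a large group, gives an at least 51-fold higher number from compound 2 to compound 4 (1.70 log units; beyond the scatter). Among the compounds shown here, this is the first step that can be read at all, and it shows that this single change at this position can move the number far upward, not downward. The value of compound 4 is a limit and not a number: the limit of > 500000 nM in this assay, at which 1 of the 4 values shown sits.

From the compounds shown here alone, whether a primary amine or a carboxylic acid on this same aromatic carbon would shift the number as far remains open. So does whether a smaller change, such as a single methylamino group, would give a step of similar size.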